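This account rests on a few compounds, and the source may have more. Where it says the series, first, only, none or still open, it means among the compounds named here.

Compound 2 `N#C/N=C1\N(CCCCCCOc2ccc(Cl)cc2)C(=O)CCN1c1ccncc1` stands at the lower end of the two numbers in hand: in a functional assay on HepG2 cells (Homo sapiens) for cytotoxicity (a higher number here means a weaker inhibitor, a lower number a stronger inhibitor), compound 2 gives 344 nM, while compound 1 `N#C/N=C1\N(CCCCCOc2ccc(Cl)cc2)C(=O)CCN1c1ccncc1` gives 2830 nM. For the measured compounds named here, the only step measured so far is an 8.2-fold lower number from compound 1 to compound 2 (0.92 log units; beyond the scatter), a modest move but beyond the scatter. Compound 3 `N#C/N=C1\N(CCCCCCCOc2ccc(Cl)cc2)C(=O)CCN1c1ccncc1` extends the same chain by one more link: (4-chlorophenoxy)methyl in place of 4-chlorophenoxy on a saturated chain carbon, six bonds along the chain from an amide-type nitrogen in a ring. Going by the values given here, the single step bearing on it is that from compound 1 to compound 2, the same change cut one bond nearer the ring; nothing shows whether a further extension continues the drop, levels off, or reverses. With one step only, a smaller move in the same direction is taken as the working expectation, and the step from compound 2 to compound 3 is expected at a 1.7-fold lower number from compound 2 to compound 3 (0.24 log units; within the scatter). For compound 3 the estimate in this assay is therefore 200 nM, with a range of 70 nM to 700 nM.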

Compound 3, half-maximal inhibitory concentration: 4000 nM
For compound 3 the middle estimate is 20-fold (1.30 log units) below the measured one, outside the stated range (above it).
By their numbers in this assay, from the lowest: compound 2; then compounds 1 and 3 (each within the scatter of the next).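

In this assay the effect of lengthening the chain at this position does not run in one direction: the added link reverses the earlier fall, with a 12-fold higher number from compound 2 to compound 3 (1.07 log units; beyond the scatter), so a saturated chain carbon six bonds along from the amide-type nitrogen is not a place where extension continues to pay. Across both extensions the net result is a 1.4-fold higher number from compound 1 to compound 3 (0.15 log units; within the scatter), which leaves compound 2 alone at the low end of this three-member set, while compound 1 and compound 3 stay within the scatter of each other. No available evidence accounts for this reversal.

Still open, on these data alone, is whether a longer chain than that of compound 3 stays at this level or changes again. Also open, as far as these compounds go, is whether the same dependence on chain length holds when an amine or a carboxylic acid replaces the 4-chlorophenoxy end group.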